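The source may report more compounds than this note shows. Statements on the series, on what has been measured and on what is new or still open speak of the compounds shown alone.

Three compounds share a common core and differ in the groups attached to it. Compound 1 `O=c1[nH]cnc2c1c(-c1ccoc1)cn2[C@@H]1O[C@H](CO)[C@@H](O)[C@H]1O` gives 6370 nM in a functional assay on HL-60 cells (Homo sapiens) for antiproliferative activity, read by XTT assay, with a stated time of 72 h (on this read-out higher numbers stand for weaker inhibition and lower numbers for stronger inhibition), the highest number of the three. Compound 2 `Cc1ncnc2c1c(I)cn2[C@@H]1O[C@H](CO)[C@@H](O)[C@H]1O` gives 2650 nM in this assay, a lower number beyond the scatter, and compound 3 `C#Cc1cn([C@@H]2O[C@H](CO)[C@@H](O)[C@H]2O)c2ncnc(N(C)C)c12` gives 290 nM, the lowest of the set. The unmeasured compound 4 `O=c1[nH]cnc2c1c(-c1cccs1)cn2[C@@H]1O[C@H](CO)[C@@H](O)[C@H]1O` differs from compound 1 in a single group: thiophen-2-yl in place of furan-3-yl on an aromatic carbon. Going by the values given here, no measured pair shows what this swap does, so the step from compound 1 is expected to be small, most likely none beyond the scatter, as a 1.3-fold lower number from compound 1 to compound 4 (0.11 log units; within the scatter). Compound 4 is therefore expected to give about 5000 nM in this assay, with a range from 1500 nM to 16000 nM.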

Compound 4, half-maximal inhibitory concentration: > 20000 nM
Compound 4: a limit, no number; the forecaster's own chance of this, stated with the estimate: 10%; at least 4.0-fold (0.60 log units) between middle value and limit.
By their numbers in this assay, from the lowest: compound 3; then compound 2; then compound 1. At a limit, above all of these: compound 4.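

At this position, an aromatic carbon of the shared core, two rings that match in heavy-atom count and in hydrogen-bond donors and acceptors are not interchangeable. In this assay, thiophen-2-yl in place of furan-3-yl gives an at least 3.1-fold higher number from compound 1 to compound 4 (0.49 log units; beyond the scatter). For compound 4 the result is a limit, not a number: the limit of > 20000 nM in this assay, at which 1 of the 4 values shown sits.

The change alters both the hetero atom and the name's attachment position, and the compounds shown do not separate these two differences. Also open, as far as these compounds go, is how furan-2-yl, thiophen-3-yl or an amine would behave at this position.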